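This account rests on a few compounds, and the source may have more. Where it says the series, first, only, none or still open, it means among the compounds named here.

Compound 1 `CC/N=C(\S)OC[C@H]1OC(n2cnc3c(NC4CCOC4)ncnc32)[C@H](O)[C@@H]1O` gives 33 nM in an assay on DDT1 cells (Cricetulus griseus) for binding affinity to adenosine receptor A1 (Homo sapiens), read by radioligand binding; a higher number here means a weaker inhibitor, a lower number a stronger inhibitor.
Compound 2 `CC(C)NC(=O)OC[C@H]1OC(n2cnc3c(NC4CCOC4)ncnc32)[C@H](O)[C@@H]1O` gives 78 nM in this assay.
Compound 3 `O[C@@H]1[C@@H](CO/C(S)=N/C2CCCC2)OC(n2cnc3c(NC4CCOC4)ncnc32)[C@@H]1O` gives 72 nM in this assay.

Compound 1 stands lowest of the three, so it is the strongest inhibitor measured here, with compound 3 nearest and compound 2 furthest. Compound 4 `C=CCNC(=O)OC[C@H]1OC(n2cnc3c(NC4CCOC4)ncnc32)[C@H](O)[C@@H]1O` shares the core of compound 1 and differs from it in one place: a group of 6 heavy atoms (4 carbon, 1 nitrogen, 1 oxygen; no ring) in place of a group of 5 heavy atoms (3 carbon, 1 nitrogen, 1 sulfur; no ring), on an oxygen on a saturated carbon.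

Among the compounds with values here, two measured steps bear on this. The closest is a 2.4-fold higher number from compound 1 to compound 2 (0.37 log units; beyond the scatter), where a carbamate with a branched chain replaced the same thioimidate group on the same oxygen. The other is a 2.2-fold higher number from compound 1 to compound 3 (0.34 log units; beyond the scatter), which kept the thioimidate but enlarged the group on the double-bonded nitrogen. Both moves away from compound 1 gave a modest weakening. Compound 4 carries a carbamate like compound 2 and so is expected to sit a little higher than compound 1. The expected step is a 2.1-fold higher number from compound 1 to compound 4 (0.33 log units; beyond the scatter). For compound 4 the estimate is 70 nM, with a range from 35 nM to 140 nM.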

Compound 4, inhibition constant: 524 nM
Compound 4: middle estimate off by 7.5-fold (0.87 log units), on the low side; the measured number lies above the stated range.
By their numbers in this assay, from the lowest: compound 1; then compounds 3 and 2 (each within the scatter of the next); then compound 4.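

Carrying a carbamate on this oxygen does not by itself set the number: allyl in place of isopropyl on the amide-type nitrogen gives a 6.7-fold higher number from compound 2 to compound 4 (0.83 log units; beyond the scatter) and so separates two carbamates that share everything else. Within the data shown here, compound 4 also stands well apart from both thioimidates, with a 16-fold higher number from compound 1 to compound 4 (1.20 log units; beyond the scatter) as a large step and a 7.3-fold higher number from compound 3 to compound 4 (0.86 log units; beyond the scatter) as a further one, so changes at this position are not limited to the modest steps seen among the earlier compounds. Nothing available here explains why the allyl carbamate sits so much higher.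

Still open, from the compounds shown here alone, is whether the second double bond of allyl matters or the shape of the chain does, which a propyl group on the same nitrogen would help to separate. An ethyl carbamate would also set the carbamate against compound 1 with the nitrogen's group unchanged.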